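Methyl for hydrogen on the phenol oxygen of the styryl lactone series

The source may report more compounds than this note shows. Statements on the series, on what has been measured and on what is new or still open speak of the compounds shown alone.

Measured compounds:
compound 1 `COc1ccc(/C=C/C2(C)C=CC(=O)O2)c(OC)c1OC` in a functional assay on U-251 cells (Homo sapiens) for inhibition, read by sulforhodamine B assay, with a stated time of 48 h (on this read-out lower numbers stand for stronger inhibition of growth and higher numbers for weaker inhibition of growth), compound 1 gives 87200 nM
compound 2 `COc1c(O)ccc(/C=C/C2(C)C=CC(=O)O2)c1OC` in this assay compound 2 gives 40700 nM
compound 3 `CC1(/C=C/c2ccccc2O)C=CC(=O)O1` in this assay compound 3 gives 70900 nM

Compound 4 `COc1ccccc1/C=C/C1(C)C=CC(=O)O1` has not been measured. It differs from compound 3 by methyl in place of hydrogen on an oxygen on an aromatic ring. The same change separates compound 2 from compound 1, (methyl in place of hydrogen on an oxygen on an aromatic ring), and the two place lines read word for word alike, so this is the same change made on two different cores. How the core of compound 3 differs from that of compound 2 is not broken down here.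

The measured instance of this change gave a 2.1-fold higher number from compound 2 to compound 1 (0.33 log units; beyond the scatter). Among the three measured compounds, compound 3 and compound 1 lie within the scatter of each other, as do compound 3 and compound 2.

For the measured compounds named here, with only one measured instance to lean on, a step of similar direction and size is expected from compound 3 to compound 4, a 1.8-fold higher number from compound 3 to compound 4 (0.26 log units; within the scatter), because the earlier step of a 2.1-fold higher number from compound 2 to compound 1 (0.33 log units; beyond the scatter) went that way. Compound 4 is therefore estimated at 130000 nM, with a plausible range of 60000 nM to 280000 nM.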

Compound 4, concentration for total growth inhibition: 41100 nM
Beside the measured number, compound 4's estimate is 3.2-fold (0.50 log units) above it, and the stated range ends above it.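

In this assay, methyl in place of hydrogen on the oxygen on the aromatic ring gives a 1.7-fold lower number from compound 3 to compound 4 (0.24 log units; within the scatter), so on this core the change leaves the number within the usual scatter. Set beside the earlier step, the change does not carry over as a fixed increment from one core to the other: the same change on two cores in this assay, a 2.1-fold higher number (0.33 log units; beyond the scatter) from compound 2 to compound 1 and a 1.7-fold lower number (0.24 log units; within the scatter) from compound 3 to compound 4, 3.7-fold (0.57 log units) apart, beyond the scatter of two such steps

This shows that the step measured on one core was a poor guide to the step on the other, but it does not establish a true reversal of direction, since the new step itself lies within the scatter, and two instances give no rule for other cores of the series.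

Going by these compounds, what remains open is whether the gap between the two steps follows the additional methoxy groups on the core of compound 1 or some other difference between the cores. Also open, on these data alone, is how a longer chain on the same oxygen, such as ethyl, or an amine in place of that oxygen, would read in this assay.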